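From azidomethyl to dimethylcarbamoyl on a shared core

This account rests on a few compounds, and the source may have more. Where it says the series, first, only, none or still open, it means among the compounds named here.

- compound 1 `CC(C)=CCC[C@]1(C)/C=C/[C@@H](OC(=O)C=C(C)C)[C@](C)(O)/C=C/C(=O)/C(CN(C)C)=C\C1` gives 140 nM
- compound 2 `CC(C)=CCC[C@]1(C)/C=C/[C@@H](OC(=O)C=C(C)C)[C@](C)(O)/C=C/C(=O)/C(CN=[N+]=[N-])=C\C1` gives 910 nM

In a functional assay on HL-60 cells (Homo sapiens) for antiproliferative activity, read by MTT assay, with a stated time of 48 h (on this read-out lower numbers stand for stronger inhibition and higher numbers for weaker inhibition), compound 2 has the higher number of the two, so it is the weaker inhibitor. Compound 3 `CC(C)=CCC[C@]1(C)/C=C/[C@@H](OC(=O)C=C(C)C)[C@](C)(O)/C=C/C(=O)/C(C(=O)N(C)C)=C\C1` carries dimethylcarbamoyl in place of azidomethyl on a double-bonded ring carbon. Going by the values given here, one measured step bears on this: azido in place of dimethylamino gave a 6.5-fold higher number from compound 1 to compound 2 (0.81 log units; beyond the scatter), a modest change beyond the scatter. That step involved no carbonyl, so it only loosely suggests a small move back toward compound 1 in this assay. The expected change is small (a 1.5-fold lower number from compound 2 to compound 3 (0.18 log units; within the scatter)). Compound 3 is estimated at 600 nM (expected range 150 nM to 2500 nM).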

Compound 3, half-maximal inhibitory concentration: 3340 nM
For compound 3 the middle estimate is 5.6-fold (0.75 log units) below the measured one; measured number outside the range, above it.
By their numbers in this assay, from the lowest: compound 1; then compound 2; then compound 3.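

In this assay, dimethylcarbamoyl in place of azidomethyl gives a 3.7-fold higher number from compound 2 to compound 3 (0.56 log units; beyond the scatter), and in place of (dimethylamino)methyl it gives a 24-fold higher number from compound 1 to compound 3 (1.38 log units; beyond the scatter), the largest step in this set. The position on the double-bonded ring carbon therefore separates these three groups clearly, and dimethylcarbamoyl, with its carbonyl bound directly to that carbon, goes with the weakest inhibition of the three. Nothing available gives a reason for this order. As far as these compounds go, it remains open whether a primary amine, a carboxylic acid or a longer chain ending in dimethylamino would sit nearer compound 1 or compound 3 .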